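Swapping Ethyl for 4-Bromophenyl on an Aromatic Nitrogen

The source may report more compounds than this note shows. Statements on the series, on what has been measured and on what is new or still open speak of the compounds shown alone.

Compound 1 `CCn1ccnc1-c1cc(OC)c(OC)c(OC)c1`: > 100000 nM
Compound 2 `COc1cc(-c2nccn2-c2cccc([N+](=O)[O-])c2)cc(OC)c1OC`: 7200 nM

In a functional assay on MDA-MB-468 cells (Homo sapiens) for antiproliferative activity, read by MTT assay, with a stated time of 72 h (a lower number here means a stronger inhibitor, a higher number a weaker inhibitor), compound 1 reaches only a limit, > 100000 nM (the limit of > 100000 nM in this assay, at which 1 of the 2 values shown sits). In this assay compound 2 gives 7200 nM. Compound 3 `COc1cc(-c2nccn2-c2ccc(Br)cc2)cc(OC)c1OC` differs from compound 1 by 4-bromophenyl in place of ethyl on an aromatic nitrogen. Because compound 2 gives 7200 nM, an aromatic group on that nitrogen is expected to give compound 3 a measurable value in this assay. The expected step is an at least 8.3-fold lower number from compound 1 to compound 3 (0.92 log units; beyond the scatter), toward stronger inhibition and beyond the usual scatter. Compound 3 is estimated at 12000 nM, between 2500 nM and 60000 nM.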

Compound 3, half-maximal inhibitory concentration: 2700 nM
Estimate against measurement, compound 3: 4.4-fold (0.65 log units) above; measured number inside the range.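

In this assay compound 1 stands at a limit, > 100000 nM, which is not a number. Putting 4-bromophenyl in place of ethyl on this aromatic nitrogen gives an at least 37-fold lower number from compound 1 to compound 3 (1.56 log units; beyond the scatter), a large step that takes this single position from the limit to a measured value. The true size of that step remains unfixed, and it can be read only as a bound: the limit of > 100000 nM in this assay, at which 1 of the 3 values shown sits.

As far as these compounds go, whether plain phenyl without the bromine, or a longer chain on that nitrogen, would also give a measured value stays open. So does how an amine or a carboxylic acid in place of the bromine would read in this assay.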